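The compounds below may be only part of what the source reports. "The series", "measured", "known", "first", "only" and "open" are said of these compounds alone.

Measured so far:

Compound 1, `O=C(/N=C(/NC(=O)c1cccs1)[Se]Cc1ccccc1)c1cccs1`: in a functional assay on HepG2 cells (Homo sapiens) for cytotoxicity, read by MTT assay, with a stated time of 72 h (on this read-out higher numbers stand for lower toxicity in this test and lower numbers for higher toxicity in this test), compound 1 gives 81500 nM.
Compound 2, `CS/C(=N\C(=O)c1cccs1)NC(=O)c1cccs1`: in this assay compound 2 gives > 100000 nM, which is a limit of the assay rather than a number.
Compound 3, `CS/C(=N\C(=O)c1cnc2ccccc2c1)NC(=O)c1cnc2ccccc2c1`: in this assay compound 3 gives > 100000 nM, again a limit of the assay rather than a number.

Compound 4, `O=C(/N=C(/NC(=O)c1cnc2ccccc2c1)[Se]Cc1ccccc1)c1cnc2ccccc2c1`, has not yet been measured. It is related to compound 3 in the same way that compound 1 is related to compound 2. Between compound 2 and compound 1 the change is a group of 8 heavy atoms (7 carbon, 1 selenium; one six-membered aromatic ring of carbon only) in place of a group of 2 heavy atoms (1 carbon, 1 sulfur; no ring), on a carbon with a double bond to nitrogen, and it made an at least 1.2-fold lower number from compound 2 to compound 1 (0.08 log units; that floor lies within the scatter). Compound 2 and compound 3 carry different cores, and the difference between the two cores is not broken down here. The change from compound 3 to compound 4 is a group of 8 heavy atoms (7 carbon, 1 selenium; one six-membered aromatic ring of carbon only) in place of a group of 2 heavy atoms (1 carbon, 1 sulfur; no ring), on a carbon with a double bond to nitrogen, the same change, made on a compound that itself sits at the limit.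

Going by the values given here, the picture in this assay is therefore thin: the limit of > 100000 nM in this assay, at which 2 of the 3 values shown sit, so the one measured step starts from a limit and its true size is not known, only its floor. For compound 4 the expected step is an at least 1.2-fold lower number from compound 3 to compound 4 (0.09 log units; that floor lies within the scatter), an expectation of an outcome that stays close to the limit. On that footing compound 4 is estimated at 80000 nM, expected to lie somewhere between 30000 nM and 150000 nM.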

Compound 4, concentration lethal to 50% of the cells: 90300 nM
For compound 4 the middle estimate is 1.1-fold (0.05 log units) below the measured one; the range from low to high includes it.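

In this assay, putting the group of seven carbons and one selenium, with its six-membered aromatic ring, in place of methylsulfanyl on the carbon with a double bond to nitrogen gives an at least 1.1-fold lower number from compound 3 to compound 4 (0.04 log units; that floor lies within the scatter), and this second core can now be set beside the first: the same change on two cores in this assay, an at least 1.2-fold lower number (0.08 log units; that floor lies within the scatter) from compound 2 to compound 1 and an at least 1.1-fold lower number (0.04 log units; that floor lies within the scatter) from compound 3 to compound 4; the limit leaves it open whether they differ

What this shows is modest: on both cores the parent compound sits at a limit of the assay, while the compound carrying the larger group gives a measured number, so the change behaves in the same general way on the two cores shown. It does not show how large the change really is on either core, or whether it is larger on one than on the other, because each step starts from a limit and only a floor can be read, a floor that lies within the usual scatter: the limit of > 100000 nM in this assay, at which 2 of the 4 values shown sit.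

The compounds shown leave open which part of the entering group matters, the selenium or the aromatic ring, since the two always arrive together. A methylselanyl group, which keeps the selenium without the ring, and a benzylsulfanyl group, which keeps the ring with sulfur in place of selenium, would separate the two, and an amine on the same carbon remains an open question as well.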